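This account rests on a few compounds, and the source may have more. Where it says the series, first, only, none or still open, it means among the compounds named here.

Measured so far:
- compound 1 `CCCCNC(=O)N1CC1C#N`: 12000 nM
- compound 2 `CCOC(=O)c1ccc(NC(=O)N2CC2C#N)cc1`: 9700 nM

In a functional assay on L1210 cells (Mus musculus) for inhibition, read by MTT assay (a lower number here means a stronger inhibitor, a higher number a weaker inhibitor), compound 2 gives 9700 nM, the lower of the two numbers shown, but the gap to compound 1, which gives 12000 nM, is within the scatter, so the two compounds are not separated. Both carry the same cyanoaziridine urea core with a different substituent on the urea nitrogen, and that difference has not moved the read-out beyond the scatter.

Compound 3 `N#CC1CN1C(=O)Nc1ccc(S(N)(=O)=O)cc1` is the next step from compound 2: sulfamoyl in place of ethoxycarbonyl on an aromatic carbon. Going by the values given here, no step between measured compounds is available, so the size of this step can only be guessed from the series as it stands. Given that the substituent on the urea nitrogen has so far not shifted the number, the step from compound 2 to compound 3 is expected to be a 1.0-fold higher number from compound 2 to compound 3 (0.01 log units; within the scatter), none beyond the scatter in either direction. Compound 3 is estimated at 10000 nM, with a range from 3500 nM to 30000 nM.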

Compound 3, half-maximal inhibitory concentration: > 38000 nM
Compound 3 gave a limit, no number; the forecaster's own chance of this, stated with the estimate: 10%; at least 3.8-fold (0.57 log units) between middle value and limit.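

In this assay compound 3 gives > 38000 nM, which is a limit of the assay and not a number. Sulfamoyl in place of ethoxycarbonyl, on the aromatic carbon para to a group of 8 heavy atoms, gives an at least 3.9-fold higher number from compound 2 to compound 3 (0.59 log units; beyond the scatter), so the read-out in this series can respond to a change of substituent, something compound 1 and compound 2 did not show, as they stayed within the scatter of each other. The step has a lower bound only, and its true size stays unread: the limit of > 38000 nM in this assay, at which 1 of the 3 values shown sits.

The compounds shown leave open whether the loss follows from sulfamoyl entering or from ethoxycarbonyl leaving. A carboxylic acid, an amine or a bare hydrogen on the same aromatic carbon would help separate these two readings.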